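The source may hold more compounds than are shown below. What is called first, only, known or untested is meant among the compounds shown, and "the series" means these compounds.

Measured so far:
Compound 1, `CCc1ccc(CN[C@H]2CC(C(=O)O)=C[C@@H](OC(CC)CC)[C@@H]2NC(C)=O)cc1`, gives > 200000 nM.
Compound 2, `CCC(CC)Oc1ccc(CN[C@H]2CC(C(=O)O)=C[C@@H](OC(CC)CC)[C@@H]2NC(C)=O)cc1`, gives > 200000 nM.
Compound 3, `CCC(CC)O[C@@H]1C=C(C(=O)O)C[C@H](NCc2ccc(Oc3ccccc3)cc2)[C@H]1NC(C)=O`, gives > 200000 nM.

The numbers above come from an ADME assay on cells (Fibroblast, Gallus gallus) for cytotoxicity, read by CCK-8 assay, with a stated time of 48 h; a higher number here means that more compound is tolerated, a lower number that less compound is tolerated. From the compounds shown here alone, for compound 1 the result is not a number but a limit of the assay, > 200000 nM, so its true position on the scale is unknown. The same holds for the other two compounds, as stated by the limit of > 200000 nM in this assay, at which 3 of the 3 values shown sit, which is why the two measured steps at the same aromatic carbon, a step that the two limits leave unreadable from compound 1 to compound 2 and a step that the two limits leave unreadable from compound 1 to compound 3, cannot be read in size or direction.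

Compound 4, `CCC(CC)O[C@@H]1C=C(C(=O)O)C[C@H](NCc2ccc(-c3ccc(SC)cc3)cc2)[C@H]1NC(C)=O`, has not yet been measured. It differs from compound 1 by 4-(methylsulfanyl)phenyl in place of ethyl on an aromatic carbon. The two measured steps that changed this same aromatic carbon bear on this change, but both are hidden behind the limit, so no step beyond the scatter can be predicted in this assay in either direction. Compound 4 is therefore expected to sit again at the limit, with the step that the limit leaves unreadable from compound 1 to compound 4. The estimate for compound 4 is 250000 nM, within a range from 100000 nM to 600000 nM.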

Compound 4, half-maximal cytotoxic concentration: > 200000 nM
Compound 4: no number, only a limit; the forecaster's own chance of this, stated with the estimate: 80%; the middle value is on the limit's open side.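

In this assay compound 4 gives > 200000 nM, which is a limit of the assay and not a number. For the compounds shown here, no step from compound 1, compound 2 or compound 3 to compound 4 can be read, in size or direction: the limit of > 200000 nM in this assay, at which 4 of the 4 values shown sit. The compounds shown leave open how much of each is actually tolerated, and whether any group at this aromatic carbon changes that.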